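The source may hold more compounds than are shown below. What is called first, only, known or untested is meant among the compounds shown, and "the series" means these compounds.

Compound 1 `O=S(=O)(c1ccc(F)cc1)N1CC(c2nc(-c3cccc(Cl)c3)no2)C1` gives > 10000 nM in an assay on HEK293 cells for positive allosteric modulation of metabotropic glutamate receptor 5 (Homo sapiens), read by FLIPR (a lower number here means that less compound is needed, a higher number that more compound is needed for the effect), a limit of the assay.
Compound 2 `Cc1cccc(-c2noc(C3CN(S(=O)(=O)c4ccc(Cl)cc4)C3)n2)c1` gives > 10000 nM in this assay, again a limit.
Compound 3 `Cc1ccc(S(=O)(=O)N2CC(c3nc(-c4cccc(C)c4)no3)C2)cc1` gives > 10000 nM in this assay, also a limit.

Compound 3 thus stands where all three measured compounds stand: the limit of > 10000 nM in this assay, at which 3 of the 3 values shown sit. The step from compound 2 to compound 3, a step that the two limits leave unreadable from compound 2 to compound 3, cannot be sized. Compound 4 `Cc1cccc(-c2noc(C3CN(S(=O)(=O)c4ccc(F)cc4)C3)n2)c1` differs from compound 3 by fluoro in place of methyl on an aromatic carbon, that is 4-methylphenyl to 4-fluorophenyl. Within the data shown here, no measured step bears directly on this change. Compound 1, which also carries 4-fluorophenyl, gives > 10000 nM in this assay, a limit. Compound 4 is therefore expected to remain at the limit too, the step of a number no higher from compound 3 to compound 4 (the limit leaves the size open) amounting to nothing readable, with an estimate of 10000 nM between 3000 nM and 30000 nM.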

Compound 4, half-maximal effective concentration: > 10000 nM
Compound 4: only a limit was reported; the forecaster's own chance of this, stated with the estimate: 85%; the middle value sits exactly at the limit.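

Among these compounds, compound 4 gives > 10000 nM in this assay, a limit of the assay, so no step from compound 1, compound 2 or compound 3 to compound 4 can be read. What the compounds shown leave open is how far each lies beyond that limit, and which change would bring a measurable value: the limit of > 10000 nM in this assay, at which 4 of the 4 values shown sit.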